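Aryl Sulfonamide Swap on a Piperazinyl Benzoxazine Core

The source may hold more compounds than are shown below. What is called first, only, known or untested is meant among the compounds shown, and "the series" means these compounds.

Compound 1 `O=S(=O)(c1ccccc1F)N1CCOc2c(N3CCNCC3)cc(F)cc21` gives 0.631 nM in an assay on HEK293 cells for displacement of a labelled ligand from 5-hydroxytryptamine receptor 6 (Homo sapiens); a lower number here means a stronger inhibitor, a higher number a weaker inhibitor. Compound 2 `O=S(=O)(c1ccccc1F)N1CCOc2c(N3CCNCC3)cc(Cl)cc21` gives 0.398 nM there. Compound 3 `CC(C)(C)c1cc(N2CCNCC2)c2c(c1)N(S(=O)(=O)c1ccccc1F)CCO2` gives 7.94 nM in this assay.

Among these three numbers compound 1 stands second highest. Its nearest neighbour is compound 2, with a 1.6-fold lower number from compound 1 to compound 2 (0.20 log units; within the scatter). The step to compound 3 is the large one: a 13-fold higher number from compound 1 to compound 3 (1.10 log units; beyond the scatter). Compound 2 to compound 3 shows the same direction, a 20-fold higher number from compound 2 to compound 3 (1.30 log units; beyond the scatter).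

Compound 4 `Nc1ccc(S(=O)(=O)N2CCOc3c(N4CCNCC4)cc(F)cc32)cc1` has not yet been measured. It differs from compound 1 in one place: 4-aminophenyl in place of 2-fluorophenyl on a sulfonyl sulfur. None of the three measured steps touches the group on the sulfonyl sulfur; they all concern the substituent on the shared core, where fluoro and chloro sit close together and tert-butyl stands well apart. Within the data shown here, no measured step therefore bears directly on the change from compound 1 to compound 4, and the expectation rests on compound 1 alone as the starting point, with a wide range to cover the unaddressed change. Compound 4 is estimated to give 2 nM in this assay, within 0.3 nM to 15 nM, which corresponds to an expected 3.2-fold higher number from compound 1 to compound 4 (0.50 log units; beyond the scatter).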

Compound 4, inhibition constant: 1.26 nM
Compound 4: the middle estimate sits 1.6-fold (0.20 log units) above what was measured; measured number inside the range.
By their numbers in this assay, from the lowest: compounds 2, 1 and 4 (each within the scatter of the next, the first and the last beyond it); then compound 3.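

Swapping the group on the sulfonyl sulfur in this assay gives a 2.0-fold higher number from compound 1 to compound 4 (0.30 log units; within the scatter), so this is the one measured change at this position, and it stays within the scatter. The entering 4-aminophenyl carries a hydrogen-bond donor and a hydrogen-bond acceptor, which the leaving 2-fluorophenyl lacks, yet this step is far smaller than the one on the shared core, a 13-fold higher number from compound 1 to compound 3 (1.10 log units; beyond the scatter), where tert-butyl replaces fluoro. Nothing available explains why these two aryl groups give such similar numbers.

A single pair cannot show whether a 4-carboxyphenyl, a pyridine ring or a plain alkyl chain on the sulfonyl sulfur would also stay close to compound 1. Going by these compounds, it also remains open whether 4-aminophenyl would behave the same way with chloro or tert-butyl on the shared core.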